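This account rests on a few compounds, and the source may have more. Where it says the series, first, only, none or still open, it means among the compounds named here.

Compound 1 `Cc1ccc(S(=O)(=O)n2cc(CCCC(=O)NC3CCCCCC3)c3ccccc32)cc1`: > 250000 nM
Compound 2 `O=C(CCCc1cn(S(=O)(=O)c2cccs2)c2ccccc12)NC1CCCCCC1`: "not determined" (no result reported)

In an ADME assay on Vero cells (Chlorocebus sabaeus) for cytotoxicity, read by fluorescence and resazurin assay, with a stated time of 3 days (a lower number here means that less compound is tolerated, a higher number that more compound is tolerated), compound 1 gives > 250000 nM, which is a limit of the assay and not a number. Compound 2 has no number of its own, and its entry reads "not determined" (no result reported). For the measured compounds named here, the only reading for the pair is therefore (the limit of > 250000 nM in this assay, at which 1 of the 2 values shown sits).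

Compound 3 `Cc1cc(S(=O)(=O)n2cc(CCCC(=O)NC3CCCCCC3)c3ccccc32)c(C)cc1Cl` has yet to be measured. The change is 4-chloro-2,5-dimethylphenyl in place of thiophen-2-yl on a sulfonyl sulfur, with 4-chloro-2,5-dimethylphenyl in place of thiophen-2-yl on a sulfonyl sulfur. Going by the values given here, no measured step guides this change, so only a modest step towards less compound tolerated is expected in this assay, possibly none beyond the scatter. For compound 3, the estimated half-maximal cytotoxic concentration is 150000 nM, with an expected range of 40000 nM to 250000 nM.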

Compound 3, half-maximal cytotoxic concentration: > 250000 nM
Compound 3: no number, only a limit; the forecaster's own chance of this, stated with the estimate: 55%; middle value at least 1.6-fold (0.22 log units) away from the limit.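

In this assay, for the compounds shown here, compound 3 gives > 250000 nM, a limit of the assay and not a number, so no step from compound 1 to compound 3 can be read. The compounds shown leave open whether the group on the sulfonyl sulfur changes the concentration tolerated at all: the limit of > 250000 nM in this assay, at which 2 of the 3 values shown sit.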